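Swapping a ring amine on the shared core

A few compounds are considered here, and "the series" means these few. Any claim that something is new, unique, unknown or untested is made for them only; others in the source may bear on it.

Three compounds share a core and differ only in the group on an aromatic carbon of the pyridine ring. Compound 1 `CC(C(=O)NCc1ccc(C(F)(F)F)nc1Nc1ccc(F)cc1)c1ccc(NS(C)(=O)=O)c(F)c1` carries a (4-fluorophenyl)amino group there, and in a functional assay on CHO-K1 cells for antagonist activity at transient receptor potential cation channel subfamily V member 1 (Homo sapiens), read by FLIPR (a lower number here means a stronger inhibitor, a higher number a weaker inhibitor), compound 1 gives 39.2 nM. Compound 2 `CCCCN(C)c1nc(C(F)(F)F)ccc1CNC(=O)C(C)c1ccc(NS(C)(=O)=O)c(F)c1` carries a butyl(methyl)amino group and gives 0.8 nM. Compound 3 `CC(C(=O)NCc1ccc(C(F)(F)F)nc1N1CCCCC1C)c1ccc(NS(C)(=O)=O)c(F)c1` carries a 2-methylpiperidin-1-yl group and gives 2.9 nM. The steps are large: a 49-fold lower number from compound 1 to compound 2 (1.69 log units; beyond the scatter) and a 14-fold lower number from compound 1 to compound 3 (1.13 log units; beyond the scatter), while a 3.6-fold higher number from compound 2 to compound 3 (0.56 log units; beyond the scatter). Compound 3 thus stands second of the three, closer to compound 2 than to compound 1.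

Compound 4 `CC(C(=O)NCc1ccc(C(F)(F)F)nc1N1CCC(C)(C)CC1)c1ccc(NS(C)(=O)=O)c(F)c1` is not yet measured. It differs from compound 3 in one place: 4,4-dimethylpiperidin-1-yl in place of 2-methylpiperidin-1-yl on an aromatic carbon. Going by the values given here, the step that bears most on this change is the one from an open-chain amine to a ring amine, a 3.6-fold higher number from compound 2 to compound 3 (0.56 log units; beyond the scatter), which was only modest; no measured step compares two ring amines with each other. Because the ring amine in compound 3 already gives 2.9 nM, the move to another ring amine is expected to bring a small step, a 1.2-fold lower number from compound 3 to compound 4 (0.06 log units; within the scatter), within or near the scatter. For compound 4 the estimate is 2.5 nM, with a range from 0.8 nM to 8 nM.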

Compound 4, inhibition constant: 0.3 nM
For compound 4 the middle estimate is 8.3-fold (0.92 log units) above the measured one, and the stated range ends above it.
By their numbers in this assay, from the lowest: compound 4; then compound 2; then compound 3; then compound 1.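

At this position, the two ring amines are not interchangeable in this assay: 4,4-dimethylpiperidin-1-yl and 2-methylpiperidin-1-yl are both six-membered rings, yet the swap gives a 9.7-fold lower number from compound 3 to compound 4 (0.99 log units; beyond the scatter) and so shows that the groups on the ring matter as well as the ring itself. Open-chain and ring amines also do not fall into a simple order, since compound 3 has a higher number than compound 2, while the other ring amine gives a 2.7-fold lower number from compound 2 to compound 4 (0.43 log units; beyond the scatter) and so takes the lowest number of the series. The distance from the (4-fluorophenyl)amino group also grows, with a 130-fold lower number from compound 1 to compound 4 (2.12 log units; beyond the scatter) as the widest step in the series, but nothing available here accounts for any of these steps.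

The two ring amines differ in both the number and the place of their methyl groups, so the compounds shown cannot separate these two changes, and a plain piperidin-1-yl group would give a useful reference point. They also leave open whether a smaller pyrrolidin-1-yl ring or a morpholine ring, which carries an oxygen atom, would keep the number as low as in compound 4.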